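This account rests on a few compounds, and the source may have more. Where it says the series, first, only, none or still open, it means among the compounds named here.

Measured compounds:
compound 1 `CN1CCN(c2ccn3c(-c4ccc(NC(=O)c5ccc([N+](=O)[O-])o5)cc4)cnc3c2)CC1` with 1580 nM
compound 2 `O=C(Nc1ccc(-c2cnc3cc(C4=CCN(C5COC5)CC4)ccn23)cc1)c1ccc([N+](=O)[O-])o1` with 1100 nM
compound 3 `CC1(O)CCN(c2ccn3c(-c4ccc(NC(=O)c5ccc([N+](=O)[O-])o5)cc4)cnc3c2)CC1` with 3100 nM

In a functional assay on MGC-803 cells (Homo sapiens) for antiproliferative activity, read by CCK-8 assay, with a stated time of 72 h (on this read-out higher numbers stand for weaker inhibition and lower numbers for stronger inhibition), compound 3 gives the highest of the three numbers. Its nearest neighbour is compound 1, and the step of a 2.0-fold higher number from compound 1 to compound 3 (0.29 log units; within the scatter) stays within the scatter; its furthest is compound 2, where the step of a 2.8-fold higher number from compound 2 to compound 3 (0.45 log units; beyond the scatter) is beyond the scatter. All three compounds share the same core and differ only in the ring attached at one aromatic carbon.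

Compound 4 `O=C(Nc1ccc(-c2cnc3cc(N4CCC4)ccn23)cc1)c1ccc([N+](=O)[O-])o1` changes that same position: azetidin-1-yl in place of 4-hydroxy-4-methylpiperidin-1-yl on an aromatic carbon. The measured steps that bear on this are the two that alter the group at this carbon, a 2.0-fold higher number from compound 1 to compound 3 (0.29 log units; within the scatter) and a 2.8-fold higher number from compound 2 to compound 3 (0.45 log units; beyond the scatter), together with a 1.4-fold lower number from compound 1 to compound 2 (0.16 log units; within the scatter), which lies within the scatter. Across these three groups the numbers move by no more than a modest amount, so a small step is expected in this assay, most likely toward a lower number, since compound 3 sits at the top of the range. Compound 4 is therefore estimated at 1800 nM, between 700 nM and 4500 nM, which would mean an expected step of a 1.7-fold lower number from compound 3 to compound 4 (0.24 log units; within the scatter).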

Compound 4, half-maximal inhibitory concentration: > 5000 nM
Compound 4: a limit, no number; the forecaster's own chance of this, stated with the estimate: 5%; middle value at least 2.7-fold (0.44 log units) away from the limit.
By their numbers in this assay, from the lowest: compounds 2, 1 and 3 (each within the scatter of the next, the first and the last beyond it). At a limit, above all of these: compound 4.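

In this assay, compound 4, with azetidin-1-yl at this aromatic carbon, gives a limit of the assay and not a number: the limit of > 5000 nM in this assay, at which 1 of the 4 values shown sits.

Set against the two groups that gave the lowest numbers, this change shows an at least 4.5-fold higher number from compound 2 to compound 4 (0.65 log units; beyond the scatter) and an at least 3.1-fold higher number from compound 1 to compound 4 (0.50 log units; beyond the scatter), while the floor of an at least 1.6-fold higher number from compound 3 to compound 4 (0.20 log units; that floor lies within the scatter) leaves its order against 4-hydroxy-4-methylpiperidin-1-yl unsettled. The earlier compounds had suggested that this position tolerates change, but among these four compounds, the bare four-membered ring gives the first step at this carbon that is clearly larger than modest differences among six-membered groups would predict, at least against compound 1 and compound 2.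

Going by these compounds, how far compound 4 really lies above compound 3 stays unknown. The compounds shown also leave open whether pyrrolidin-1-yl, or an azetidine ring carrying a hydroxyl group or an amine, would read like compound 4 or like compound 1.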